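The source may hold more compounds than are shown below. What is called first, only, known or untested is meant among the compounds shown, and "the series" means these compounds.

Three compounds of one series have been characterised in a physicochemical assay for lipophilicity (on this read-out higher numbers stand for higher lipophilicity and lower numbers for lower lipophilicity), and a fourth is about to be. Compound 1 `CC(/C=C/CC(C)CCCC(C)C)=C\C(=O)OCc1ccccc1` gives 7.87 in this assay. Compound 2 `CCOC(=O)/C=C(C)/C=C/CC(C)CCCC(C)CC` gives 7.81, a number that lies within the usual scatter of the number for compound 1, so the two cannot be told apart on this read-out. Compound 3 `C=C(C)CCCC(C)C/C=C/C(C)=C/C(=O)OC(C)C` gives 6.6, a number that lies beyond the scatter below compound 1, which is thus the only clear separation among the three.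

The piece now turns to compound 4 `CC(/C=C/CC(C)CCCC(C)C)=C\C(=O)c1ccccc1`, which has not yet been measured in this assay. Compound 4 differs from compound 1 in one place: phenyl in place of benzyloxy on a carbonyl carbon. Among the measured compounds shown here, no pair among the measured compounds shows a change of this kind, so the size of the step has to be judged from the change itself. The expectation is a modest fall, a step from compound 1 to compound 4 of about a number 0.37 log units lower from compound 1 to compound 4 (beyond the scatter), close to the edge of the scatter rather than well beyond it. On that basis compound 4 is expected to give about 7.5 in this assay, with a likely range from 7 to 8.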

Compound 4, partition coefficient: 7.26
Compound 4: the middle estimate sits 0.24 log units above what was measured; measured number inside the range.
By their numbers in this assay, from the lowest: compound 3; then compound 4; then compounds 2 and 1 (each within the scatter of the next).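

Among the compounds shown here, the step of a number 0.61 log units lower from compound 1 to compound 4 (beyond the scatter) in this assay is the first clean single-place comparison, since compounds 2 and 3 each differ from compound 1 in more than one place. It shows that this read-out responds clearly to what sits on the carbonyl carbon, even when a six-membered aromatic ring of carbon is present on both sides of the change: benzyloxy, with its 8 heavy atoms and 1 hydrogen-bond acceptor, gives way to phenyl, with 6 heavy atoms and 0 hydrogen-bond acceptors. Nothing measured here explains why the number moves in this direction, so the step stands as an observation without a cause.

A single pair cannot separate the loss of the oxygen from the loss of the extra carbon, and it gives no sign of whether the same step would appear on a different chain in the rest of the molecule. Other groups on this carbonyl carbon, such as a hydroxyl group giving a carboxylic acid, a dimethylamino group giving an amide, or a longer chain ending in phenyl, remain open.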